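Sulfonohydrazide series: the acetamido-to-carboxyethyl step

The source may hold more compounds than are shown below. What is called first, only, known or untested is meant among the compounds shown, and "the series" means these compounds.

Compound 1 `CC(=O)Nc1ccc(S(=O)(=O)NNc2ccc(S(N)(=O)=O)cc2)cc1`, compound 2 `CC(=O)Nc1ccc(S(=O)(=O)NNc2ccc(C(F)(F)F)cc2)cc1` and compound 3 `CC(=O)Nc1ccc(S(=O)(=O)NNc2ccc(Br)cc2)cc1` share one core and differ only in the group on the second aromatic ring. In an assay on HeLa cells for inhibition of Indoleamine 2,3-dioxygenase 1 (Homo sapiens), read by spectrophotometry, with a stated time of 24 h (on this read-out higher numbers stand for an effect only at larger amounts of compound and lower numbers for an effect already at smaller amounts), compound 1 gives 3120 nM, compound 2 gives 181 nM and compound 3 gives 85 nM. Compound 3 has the lowest number of the three: the step of a 37-fold lower number from compound 1 to compound 3 (1.56 log units; beyond the scatter) and the step of a 2.1-fold lower number from compound 2 to compound 3 (0.33 log units; beyond the scatter) both lie beyond the scatter, as does a 17-fold lower number from compound 1 to compound 2 (1.24 log units; beyond the scatter).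

Compound 4 `O=C(O)CCc1ccc(S(=O)(=O)NNc2ccc(Br)cc2)cc1` keeps the bromo group of compound 3 and alters the other end of the molecule: 2-carboxyethyl in place of acetamido on an aromatic carbon. Among the measured compounds shown here, none of the measured steps touches this position; all three concern the ring carrying bromo, trifluoromethyl or sulfamoyl, so they give no direct guide to the size or direction of the new step. The data hold nothing on an exchange of acetamido for a carboxyl-bearing chain. The step of a 1.8-fold higher number from compound 3 to compound 4 (0.25 log units; within the scatter) is therefore the expected outcome, with no change beyond the scatter assumed in either direction but with a wide range. Compound 4 is estimated at 150 nM in this assay, with a range from 40 nM to 600 nM.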

Compound 4, half-maximal effective concentration: 183 nM
Estimate against measurement, compound 4: 1.2-fold (0.09 log units) below, within the range that was stated.
By their numbers in this assay, from the lowest: compound 3; then compounds 2 and 4 (each within the scatter of the next); then compound 1.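

In this assay, the end of the molecule carrying acetamido now has a measured step of its own: 2-carboxyethyl in place of acetamido gives a 2.2-fold higher number from compound 3 to compound 4 (0.33 log units; beyond the scatter), so the exchange moves the number beyond the scatter, and compound 4 stays at 183 nM with the bromo group retained. This change is of modest size, comparable to a 2.1-fold lower number from compound 2 to compound 3 (0.33 log units; beyond the scatter) and far smaller than a 37-fold lower number from compound 1 to compound 3 (1.56 log units; beyond the scatter), so on these four compounds the largest step remains the one involving sulfamoyl on the other ring. Nothing at hand accounts for the step at the acetamido position.

A single exchange at this position does not separate the contribution of the terminal carboxylic acid from that of the chain carrying it, so a carboxylic acid directly on an aromatic carbon, a longer chain ending in a carboxylic acid, or the methyl ester of the 2-carboxyethyl group could each fall on either side of compound 3. From the compounds shown here alone, it also remains open whether the same exchange gives a step of similar size and direction when trifluoromethyl or sulfamoyl replaces bromo on the second ring.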